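A few compounds are considered here, and "the series" means these few. Any claim that something is new, unique, unknown or untested is made for them only; others in the source may bear on it.

Series notes, cytotoxicity set.

Compound 1 `COC(=O)Cn1c2ccc([N+](=O)[O-])cc2c(=O)n1Cc1ccccc1` carries a (methoxycarbonyl)methyl chain on the ring nitrogen of the shared core of compound 1 and compound 2. In an ADME assay on L929 cells (Mus musculus) for cytotoxicity, read by resazurin assay, with a stated time of 48 h (on this read-out lower numbers stand for higher toxicity in this test and higher numbers for lower toxicity in this test), compound 1 gives 129000 nM. Compound 2 `COC(=O)CCn1c2ccc([N+](=O)[O-])cc2c(=O)n1Cc1ccccc1` bears the longer chain. In this assay compound 2 reaches only a limit of the assay, > 256000 nM. The change (methoxycarbonyl)methyl in place of methoxycarbonyl on a saturated chain carbon bound to an aromatic nitrogen thus produced an at least 1.9-fold higher number from compound 1 to compound 2 (0.29 log units; that floor lies within the scatter).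

Compound 3 `COC(=O)COc1c2cc([N+](=O)[O-])ccc2nn1Cc1ccccc1` has the same atoms as compound 1 joined differently; the difference between the two cores is not broken down here. In this assay compound 3 also sits at a limit of the assay, > 256000 nM. Note (the limit of > 256000 nM in this assay, at which 2 of the 3 values shown sit).

Compound 4 `COC(=O)CCOc1c2cc([N+](=O)[O-])ccc2nn1Cc1ccccc1` relates to compound 3 through ((methoxycarbonyl)methyl in place of methoxycarbonyl on a saturated chain carbon bound to an oxygen on an aromatic ring). This is the same kind of change as that from compound 1 to compound 2, but the place differs: there the chain sat on a saturated chain carbon bound to an aromatic nitrogen, here on a saturated chain carbon bound to an oxygen on an aromatic ring. For compound 4 a step that the limit leaves unreadable from compound 3 to compound 4 is expected. That expectation rests on compound 3 already standing at its limit. It also rests on the earlier step of an at least 1.9-fold higher number from compound 1 to compound 2 (0.29 log units; that floor lies within the scatter), which gave no lower number. Compound 4 is accordingly estimated at 300000 nM, most likely reported only as a limit.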

Compound 4, concentration lethal to 50% of the cells: > 256000 nM
Compound 4 ended at the assay's limit (the forecaster's own chance of this, stated with the estimate: 80%); the middle value is on the limit's open side.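

In this assay compound 4 stands at a limit of the assay, > 256000 nM. No size can be read for the change from compound 3 to compound 4 because both values are limits: the limit of > 256000 nM in this assay, at which 3 of the 4 values shown sit. The compounds shown leave open how far compound 2, compound 3 and compound 4 lie beyond that limit.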